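Swapping a Phenyl Tail for a Sulfamoylphenyl Tail

This account rests on a few compounds, and the source may have more. Where it says the series, first, only, none or still open, it means among the compounds named here.

Of the compounds shown here, three sharing one core have been tested in an ADME assay on Huh-7 cells (Homo sapiens) for cytotoxicity; on this read-out higher numbers stand for weaker inhibition of growth and lower numbers for stronger inhibition of growth. Compound 1 `COc1cc2c(=O)c(C(=O)c3ccc(C)cc3)cn(Cc3ccc(N)cc3)c2cc1OC` carries an aminobenzyl group on the ring nitrogen and was reported in this assay as "not active" (no number reported). Compound 2 `COc1cc2c(=O)c(C(=O)c3ccc(C)cc3)cn(CC3CCCCC3)c2cc1OC` carries a cyclohexylmethyl group instead and gives 22000 nM in this assay. Compound 3 `COc1cc2c(=O)c(C(=O)c3ccc(C)cc3)cn(CCCc3ccccc3)c2cc1OC` carries a 3-phenylpropyl group, and in this assay compound 3 was reported as "not active" (no number reported), so no number stands for it; like compound 1, it belongs among the entries that did not reach a measurable value, while compound 2 alone gives one.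

Compound 4 `COc1cc2c(=O)c(C(=O)c3ccc(C)cc3)cn(Cc3ccc(S(N)(=O)=O)cc3)c2cc1OC` is the next step from compound 3: 4-sulfamoylphenyl in place of phenethyl on a saturated chain carbon bound to an aromatic nitrogen. The group that enters brings one hydrogen-bond donor and two hydrogen-bond acceptors where the group that leaves brought none.

Among the compounds with values here, since no step between measured compounds is available, and since compound 3 itself gave no number, there is no basis for expecting a shift in either direction; the most likely outcome is again an entry without a number. Compound 4 is expected to give around 60000 nM in this assay, with a range from 20000 nM to 200000 nM.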

Compound 4, concentration for 50% growth inhibition: > 25000 nM
Compound 4: no number, only a limit; the forecaster's own chance of this, stated with the estimate: 70%; the middle value does not contradict the limit.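

Compound 4 is reported only as a limit and not as a number: the limit of > 25000 nM in this assay, at which 1 of the 4 values shown sits.

Putting 4-sulfamoylphenyl in place of cyclohexyl on a saturated chain carbon bound to an aromatic nitrogen gives an at least 1.1-fold higher number from compound 2 to compound 4 (0.05 log units; that floor lies within the scatter), so this tail is not shown to lower the number, and how much it may raise it stays unknown. The steps that involve compound 1 or compound 3, including the change from 3-phenylpropyl to 4-sulfamoylbenzyl, cannot be read, since those entries carry no number at all.

In this assay the only true number among these tails still belongs to compound 2, which gives 22000 nM, so how far compound 4 lies from compound 2 remains open, as does any part played by the sulfamoyl group itself. Also open, going by these compounds, is whether a benzyl tail with a carboxylic acid or a nitrile in place of the sulfamoyl group would give a number in this assay or would end at a limit as well.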